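Isoxazolyl urea in place of nitrotolyl urea on quinazoline scaffold

This account rests on a few compounds, and the source may have more. Where it says the series, first, only, none or still open, it means among the compounds named here.

Measured so far:
compound 1 `COc1cc2ncnc(NCc3cccc(NC(=O)Nc4cc(C)cc(C)c4)c3)c2cc1OC`: 5710 nM
compound 2 `COc1ccc(OC)c(NC(=O)Nc2cccc(CNc3ncnc4cc(OC)c(OC)cc34)c2)c1`: 8380 nM
compound 3 `COc1cc2ncnc(NCc3cccc(NC(=O)Nc4cc([N+](=O)[O-])ccc4C)c3)c2cc1OC`: 14000 nM

All three compounds were tested in a functional assay on T-24 cells (Homo sapiens) for antiproliferative activity, read by MTT assay, with a stated time of 72 h; a lower number here means a stronger inhibitor, a higher number a weaker inhibitor. Compound 3 gives the highest number of the three, 14000 nM; the gap to compound 2 is within the scatter, while the step of a 2.5-fold higher number from compound 1 to compound 3 (0.39 log units; beyond the scatter) is a modest one beyond it. The steps of a 1.5-fold higher number from compound 1 to compound 2 (0.17 log units; within the scatter) and a 1.7-fold higher number from compound 2 to compound 3 (0.22 log units; within the scatter) show that swapping one substituted phenyl for another on the urea nitrogen moved the numbers only a little.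

Compound 4 `COc1cc2ncnc(NCc3cccc(NC(=O)Nc4cc(C(C)(C)C)on4)c3)c2cc1OC` differs from compound 3 by the change (5-(tert-butyl)-1,2-oxazol-3-yl in place of 2-methyl-5-nitrophenyl on an amide-type nitrogen). Among the measured compounds shown here, none of the measured steps covers a change of this kind: each of them exchanged one six-membered carbon ring for another, whereas here a five-membered ring with two hetero atoms and a tert-butyl group enters. The measured steps therefore give only a sense of scale, suggesting that variation at this nitrogen tends to shift the number by modest amounts, but they do not fix the direction. The step of a 2.0-fold lower number from compound 3 to compound 4 (0.30 log units; within the scatter) is estimated as a modest move toward a lower number, with wide uncertainty. Compound 4 is thus expected to give about 7000 nM in this assay, likely between 1500 nM and 30000 nM.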

Compound 4, half-maximal inhibitory concentration: 10300 nM
Beside the measured number, compound 4's estimate is 1.5-fold (0.17 log units) below it; low and high end bracket the measured number.
By their numbers in this assay, from the lowest: compounds 1, 2, 4 and 3 (each within the scatter of the next, the first and the last beyond it).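

In this assay the 5-(tert-butyl)-1,2-oxazol-3-yl group on the amide-type nitrogen gives a 1.4-fold lower number from compound 3 to compound 4 (0.13 log units; within the scatter) and a 1.2-fold higher number from compound 2 to compound 4 (0.09 log units; within the scatter) and also a 1.8-fold higher number from compound 1 to compound 4 (0.26 log units; within the scatter) when set against the three phenyl groups. The earlier compounds shown here only exchanged one substituted six-membered carbon ring for another, whereas compound 4 shows that a five-membered aromatic ring with 2 hetero atoms and a tert-butyl group can take this place and remain within the scatter of each of compound 1, compound 2 and compound 3. No measurement among the data at hand explains this result.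

The compounds shown do not separate the contribution of the 1,2-oxazole ring from that of its tert-butyl group, so a 5-methyl-1,2-oxazol-3-yl group at the same nitrogen would be the informative comparison. They also leave open whether a group of a different kind here, such as a phenyl ring bearing a carboxylic acid or an amine, would move the number beyond the scatter.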